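Extending the phenethyl chain of compound 2 with a phenoxy group

The source may report more compounds than this note shows. Statements on the series, on what has been measured and on what is new or still open speak of the compounds shown alone.

Measured compounds:
- compound 1, `Nc1nc(NCc2ccccc2Cl)nc(-c2ccccc2CO)n1`, 5.07
- compound 2, `Nc1nc(NCCCc2ccccc2)nc(-c2ccccc2CO)n1`, 5.22

In a functional assay on cells for positive allosteric modulation of G-protein coupled receptor 68 (Homo sapiens), read by a luciferase reporter and cAMP accumulation, with a stated time of 30 min, at pH 6.8 and pH 8.3, in the presence of a further agent that is not named here (a higher number here means a more potent compound, by a factor of ten per unit of this negative logarithm, a lower number a less potent compound), compound 2 gives 5.22, the highest of the two numbers, though its nearest neighbour compound 1 gives 5.07 and the step of a number 0.15 log units higher from compound 1 to compound 2 (within the scatter) lies within the scatter, so the two cannot be ranked. Compound 3, `Nc1nc(NCCCc2ccc(Oc3ccccc3)cc2)nc(-c2ccccc2CO)n1`, is not yet measured. It differs from compound 2 by phenoxy in place of hydrogen on an aromatic carbon. Among the compounds with values here, no measured step touches that part of the molecule; the only step, a number 0.15 log units higher from compound 1 to compound 2 (within the scatter), changed the group on the chain itself and was small. On this basis little is known, and the expectation for the step of a number 0.18 log units higher from compound 2 to compound 3 (within the scatter) is a small change with a wide range. Compound 3 is therefore estimated to give 5.4, between 4.8 and 6.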

Compound 3, negative logarithm of the antagonist equilibrium constant: 4.67
The estimate for compound 3 lay 0.73 log units above the measured number; measured number outside the range, below it.
By their numbers in this assay, from the lowest: compound 3; then compounds 1 and 2 (each within the scatter of the next).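

In this assay, placing phenoxy on this aromatic carbon, para to a large group, gives a number 0.55 log units lower from compound 2 to compound 3 (beyond the scatter) in this series. The earlier step, a number 0.15 log units higher from compound 1 to compound 2 (within the scatter), changed the group on the chain and could not separate its two compounds, whereas this one shows that a change on the aromatic ring of that side chain can move the number by more than the usual scatter, and here it moves it down. Nothing measured in this set accounts for the drop.

One substituent at one position cannot show whether any group on this carbon lowers the number or only phenoxy does. Methoxy, fluorine, an amine or a carboxylic acid on the same carbon would each test this, and a longer chain carrying phenoxy would test how the chain and the ring work together.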